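Amino substitution on the shared core: a sparse series

A few compounds are considered here, and "the series" means these few. Any claim that something is new, unique, unknown or untested is made for them only; others in the source may bear on it.

Measured so far:
compound 1 `C#Cc1cn([C@@H]2O[C@H](CO)[C@@H](O)[C@H]2O)c2nc(N)nc(OC)c12` — > 100000 nM
compound 2 `C#Cc1cn([C@@H]2O[C@H](CO)[C@@H](O)[C@H]2O)c2ncnc(OC)c12` — 8160 nM
compound 3 `O=c1[nH]cnc2c1c(-c1ccccc1)cn2[C@@H]1O[C@H](CO)[C@@H](O)[C@H]1O` — > 100000 nM

In a functional assay on A549 cells (Homo sapiens), read by MTT assay, with a stated time of 72 h (a lower number here means a stronger inhibitor, a higher number a weaker inhibitor), compound 2 gives 8160 nM. Compound 1 gives > 100000 nM, which is a limit of the assay. The change amino in place of hydrogen on an aromatic carbon therefore makes an at least 12-fold higher number from compound 2 to compound 1 (1.08 log units; beyond the scatter), a step that ends at the limit of > 100000 nM in this assay, at which 2 of the 3 values shown sit. Compound 3 gives > 100000 nM, also a limit. The difference between the core of compound 3 and the core of compound 2 is not broken down here. Compound 4 `Nc1nc2c(c(-c3ccccc3)cn2[C@@H]2O[C@H](CO)[C@@H](O)[C@H]2O)c(=O)[nH]1` is not yet measured; it differs from compound 3 by amino in place of hydrogen on an aromatic carbon, the same kind of change as from compound 2 to compound 1, though there the place is meta to a methoxy group (2 heavy atoms) whereas here it is meta to a group of 1 heavy atom. Because the earlier step was an at least 12-fold higher number from compound 2 to compound 1 (1.08 log units; beyond the scatter) and compound 3 already sits at the limit of > 100000 nM in this assay, at which 2 of the 3 values shown sit, compound 4 is expected to remain at the limit, an expected step that the limit leaves unreadable from compound 3 to compound 4. Compound 4 is estimated at 150000 nM, with an expected range from 60000 nM to 1000000 nM.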

Compound 4, half-maximal inhibitory concentration: > 100000 nM
Compound 4: no number, only a limit; the forecaster's own chance of this, stated with the estimate: 90%; the middle value is on the limit's open side.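

Compound 3 and compound 4 are both limits, not numbers, so the step between them cannot be read: the limit of > 100000 nM in this assay, at which 3 of the 4 values shown sit.

The compounds shown leave open what amino in place of hydrogen on an aromatic carbon does on the core of compound 3.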